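The compounds below may be only part of what the source reports. "The series", "measured", "known", "first", "only" and "open" are said of these compounds alone.

In a functional assay on HCT-116 cells (Homo sapiens) for antiproliferative activity, read by MTT assay, with a stated time of 48 h (a lower number here means a stronger inhibitor, a higher number a weaker inhibitor), compound 1 (`CC(CCO)n1cnc2c(Cl)ncnc21`) gives > 50000 nM as its reading, which is a limit and not a number. Compound 3 (`CCCCC(CCO)n1cnc2c(N)ncnc21`) gives > 50000 nM as its reading, again only a limit. Compound 2 (`CCCCC(CCO)n1cnc2c(Cl)nc(F)nc21`) gives 13500 nM as a true number. Compound 4 (`CCCCCC(CCO)n1cnc2c(Cl)ncnc21`) differs from compound 1 by butyl in place of hydrogen on a saturated chain carbon, two bonds along the chain from an aromatic nitrogen in the form of butyl in place of hydrogen on a saturated chain carbon, two bonds along the chain from an aromatic nitrogen. A modest shift towards stronger inhibition in this assay is expected, resting only on compound 2 with its 13500 nM reading. For compound 4 another limit remains possible. The estimated step is an at least 2.5-fold lower number from compound 1 to compound 4 (0.39 log units; beyond the scatter) on these few data. Compound 4 is expected at 20000 nM with an estimated range of 8000 nM to 50000 nM in this assay.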

Compound 4, half-maximal inhibitory concentration: > 50000 nM
Compound 4: no number, only a limit; the forecaster's own chance of this, stated with the estimate: 35%; middle value at least 2.5-fold (0.39 log units) away from the limit.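

Compound 1 and compound 4 each give only a limit in this assay, so no step can be read between them: the limit of > 50000 nM in this assay, at which 3 of the 4 values shown sit.
Going by these compounds, how far butyl in place of hydrogen moves the reading of compound 1 remains open.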